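Antiproliferative series: methyl removal and fluoro removal steps

The compounds below may be only part of what the source reports. "The series", "measured", "known", "first", "only" and "open" are said of these compounds alone.

Measured compounds:
- compound 1, `COc1cccc(CNCc2c(C(=O)O)n(Cc3ccccc3F)c3cc(C)ccc23)c1`. In a functional assay on Bel-7402 cells (Homo sapiens) for antiproliferative activity, read by MTT assay, with a stated time of 72 h (a lower number here means a stronger inhibitor, a higher number a weaker inhibitor), compound 1 gives only the assay limit > 50000 nM.
- compound 2, `COc1cccc(CNCc2c(C(=O)O)n(Cc3ccccc3F)c3ccccc23)c1`. In this assay compound 2 likewise gives only the assay limit > 50000 nM.
- compound 3, `COc1cccc(CNCc2c(C(=O)O)n(Cc3ccccc3)c3cc(C)ccc23)c1`. In this assay, within the data shown here, compound 3 gives 12500 nM, the only real number in the set.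

From compound 1 to compound 2 the change is hydrogen in place of methyl on an aromatic carbon. The step that the two limits leave unreadable from compound 1 to compound 2 cannot be sized because of the limit of > 50000 nM in this assay, at which 2 of the 3 values shown sit. From compound 1 to compound 3 the cores differ by hydrogen in place of fluoro on an aromatic carbon, and the step of an at least 4.0-fold lower number from compound 1 to compound 3 (0.60 log units; beyond the scatter) is the one readable movement in the set, though its true size is open at the far end.

Compound 4, `COc1cccc(CNCc2c(C(=O)O)n(Cc3ccccc3)c3ccccc23)c1`, has not yet been measured. It differs from compound 3 by hydrogen in place of methyl on an aromatic carbon, the same change as that from compound 1 to compound 2, at the same place. Among the measured compounds shown here, that earlier instance left no readable step, so there is no precedent to carry over.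

For compound 4 the expected step is a 1.4-fold higher number from compound 3 to compound 4 (0.16 log units; within the scatter), resting only on the value of compound 3, 12500 nM, and on the absence of any sized movement for this change. The estimate for compound 4 is accordingly 18000 nM, with a range from 6000 nM to 50000 nM, and a real chance that this assay again returns only a limit.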

Compound 4, half-maximal inhibitory concentration: > 50000 nM
Compound 4: no number, only a limit; the forecaster's own chance of this, stated with the estimate: 35%; middle value at least 2.7-fold (0.44 log units) from the limit.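

In this assay, on these data alone, hydrogen in place of methyl on an aromatic carbon gives an at least 4.0-fold higher number from compound 3 to compound 4 (0.60 log units; beyond the scatter), so on the core of compound 3 the loss of the methyl moves the read-out beyond the scatter, though the full size of that step stays open. Compound 4 gives > 50000 nM, which is a limit of the assay and not a number. This is the only sized instance of the change, and it cannot be said to carry to the fluoro-bearing core, since the step from compound 1 to compound 2 and the step from compound 2 to compound 4 cannot be read, because both ends of each are limits: the limit of > 50000 nM in this assay, at which 3 of the 4 values shown sit.

The compounds shown leave open whether a chloro or an ethyl group on the same aromatic carbon would give a real number in this assay, as the methyl of compound 3 does. They also leave open whether an amide or a methyl ester in place of the carboxylic acid would bring compound 1, compound 2 or compound 4 off the limit.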